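A few compounds are considered here, and "the series" means these few. Any claim that something is new, unique, unknown or untested is made for them only; others in the source may bear on it.

Measured so far in a functional assay on the whole organism for antagonist activity, with Mus musculus as the target; a higher number here means that more compound is needed for the effect, a lower number that less compound is needed:
- compound 1 `CN(C(=O)CNC(=O)CN1CCCCC1)c1ccc(Cl)cc1C(=O)c1ccccc1Cl`: 7.5 mg/kg
- compound 2 `CC(C)NCC(=O)NCC(=O)N(C)c1ccc(Cl)cc1C(=O)c1ccccc1Cl`: 1 mg/kg
- compound 3 `CCC(=O)NCC(=O)N(C)c1ccc(Cl)cc1C(=O)c1ccccc1Cl`: 1.4 mg/kg

Compound 3 cannot be told apart from compound 2, since the step of a 1.4-fold higher number from compound 2 to compound 3 (0.15 log units; within the scatter) stays within the scatter. Compound 1 has the clearly highest number, and the step of a 5.4-fold lower number from compound 1 to compound 3 (0.73 log units; beyond the scatter) lies beyond the scatter.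

Compound 4 `CC(C)C(=O)NCC(=O)N(C)c1ccc(Cl)cc1C(=O)c1ccccc1Cl` extends compound 3 by one small change, from propanoyl to isopropylcarbonyl: methyl in place of hydrogen on a saturated chain carbon bound to a carbonyl carbon and a saturated chain carbon. Among the compounds with values here, no measured step makes this exact change. The nearest evidence comes from steps that alter a group on a saturated chain carbon bound to a carbonyl carbon. The step of a 7.5-fold lower number from compound 1 to compound 2 (0.88 log units; beyond the scatter) is modest, but it removes piperidin-1-yl, a much larger change than the one here. The step of a 1.4-fold higher number from compound 2 to compound 3 (0.15 log units; within the scatter) is the closer guide, and it shows no change beyond the scatter. No shift beyond the scatter is therefore expected in this assay, in either direction.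

The expected step is a 1.1-fold higher number from compound 3 to compound 4 (0.03 log units; within the scatter). Compound 4 is estimated at 1.5 mg/kg, with an expected range of 0.7 mg/kg to 3.5 mg/kg.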

Compound 4, dose for half-maximal effect: 6 mg/kg
Compound 4: middle estimate off by 4.0-fold (0.60 log units), on the low side; the whole stated range lies below it.
By their numbers in this assay, from the lowest: compounds 2 and 3 (each within the scatter of the next); then compounds 4 and 1 (each within the scatter of the next).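

In this assay, within the data shown here, the methyl that turns ethyl into isopropyl, on a saturated chain carbon bound to a carbonyl carbon and a saturated chain carbon, is not a silent change: it gives a step beyond the scatter (a 4.3-fold higher number from compound 3 to compound 4 (0.63 log units; beyond the scatter)), which shows that this position responds to one added carbon, something the earlier compounds did not show. Compound 4 also separates from compound 2 (a 6.0-fold higher number from compound 2 to compound 4 (0.78 log units; beyond the scatter)). Compound 4 cannot be told apart from compound 1 (a 1.3-fold lower number from compound 1 to compound 4 (0.10 log units; within the scatter)), so the small isopropyl group here matches the much larger (piperidin-1-yl)methyl group in this assay.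

On these data alone, whether a tert-butyl group or a longer chain such as butanoyl at this place would push the number further remains open. No measurement shown explains why this single methyl matters.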